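Adding one hydroxy to compound 3

This account rests on a few compounds, and the source may have more. Where it says the series, first, only, none or still open, it means among the compounds named here.

In a functional assay, with a stated time of 30 min (a higher number here means a weaker inhibitor, a lower number a stronger inhibitor), compound 1 (`O=C(/C=C/c1ccc(O)c(O)c1)CC(=O)/C=C/c1cccc(O)c1O`) gives 19000 nM and compound 2 (`O=C(/C=C/c1ccccc1O)CC(=O)c1ccc(O)c(O)c1`) gives 16000 nM while compound 3 (`O=C(/C=C/c1cccc(O)c1)CC(=O)c1ccc(O)c(O)c1`) gives 10000 nM in the same test. All three lie within the scatter of one another, so compound 3 cannot be separated from the other two on these numbers.

Compound 4 (`O=C(/C=C/c1cc(O)ccc1O)CC(=O)c1ccc(O)c(O)c1`) differs from compound 3 by one change (hydroxy in place of hydrogen on an aromatic carbon), a hydroxy in place of hydrogen on an aromatic carbon, ortho to a large group and para to a hydroxy group. Going by the values given here, the one measured step at this end of the molecule is a 1.6-fold lower number from compound 2 to compound 3 (0.20 log units; within the scatter) and it exchanges 2-hydroxyphenyl for 3-hydroxyphenyl without adding a hydroxy. Among the compounds with values here, it is therefore only a weak guide, and the data hold no step that adds one. No shift beyond the scatter is expected in this assay for now. The expected step is a 1.3-fold lower number from compound 3 to compound 4 (0.10 log units; within the scatter) on this estimate. For compound 4 the estimate is 8000 nM with 3000 nM to 20000 nM as its expected range.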

Compound 4, half-maximal inhibitory concentration: 82000 nM
Estimate against measurement, compound 4: 10-fold (1.01 log units) below, and the stated range ends below it.
By their numbers in this assay, from the lowest: compounds 3, 2 and 1 (each within the scatter of the next); then compound 4.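

In this assay, moving a single hydroxy around this ring had produced no step beyond the scatter, whereas adding a second hydroxy on this aromatic carbon, ortho to a large group and para to a hydroxy group, gives an 8.2-fold higher number from compound 3 to compound 4 (0.91 log units; beyond the scatter). The comparison with the other single-hydroxy compound points the same way, with a 5.1-fold higher number from compound 2 to compound 4 (0.71 log units; beyond the scatter). So this ring accepts a shift of its hydroxy with no measurable change, but the added hydroxy here gives a weaker inhibitor; no measurement available bears on the reason for this.

The compounds shown leave open whether this weakening is specific to hydroxy or would also follow a methoxy, a fluorine or an amine on the same carbon. They also leave open whether a hydroxy added at another carbon of this ring would give the same result.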